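This account rests on a few compounds, and the source may have more. Where it says the series, first, only, none or still open, it means among the compounds named here.

For the measured compounds named here, compound 2 `C#CC(=O)N1C(CCCC)SC[C@@H]1C(=O)OCC` stands at the lowest of the two numbers measured so far. In a functional assay on Huh-7 cells (Homo sapiens) for inhibition, read by sulforhodamine B assay (on this read-out higher numbers stand for weaker inhibition and lower numbers for stronger inhibition), compound 2 gives 500 nM, while compound 1 `C#CC(=O)N1C(c2cccc(F)c2)SC[C@@H]1C(=O)OCC` gives 1400 nM. That gap is a 2.8-fold lower number from compound 1 to compound 2 (0.45 log units; beyond the scatter). Compound 3 `C#CC(=O)N1C(C(C)CCC)SC[C@@H]1C(=O)OCC` differs from compound 2 by methyl in place of hydrogen on a saturated chain carbon bound to a saturated chain carbon and a saturated ring carbon. Going by the values given here, the only measured step exchanged a whole ring for a chain, so it bears only loosely on adding a single methyl to that chain, and no step beyond the scatter is expected in this assay. Compound 3 is therefore estimated at 500 nM, between 200 nM and 1300 nM. The expected change is no change at the digits printed from compound 2 to compound 3 (within the scatter).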

Compound 3, half-maximal inhibitory concentration: 600 nM
For compound 3 the middle estimate is 1.2-fold (0.08 log units) below the measured one; the measured number falls inside the stated range.
By their numbers in this assay, from the lowest: compounds 2 and 3 (each within the scatter of the next); then compound 1.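

Putting a methyl on the saturated chain carbon bound to a saturated chain carbon and a saturated ring carbon, which turns butyl into 1-methylbutyl, leaves this assay within the scatter (a 1.2-fold higher number from compound 2 to compound 3 (0.08 log units; within the scatter)). So this branch is tolerated here, and 1-methylbutyl also stays ahead of 3-fluorophenyl (a 2.3-fold lower number from compound 1 to compound 3 (0.37 log units; beyond the scatter)). No supporting data explain either result. Still open, from the compounds shown here alone, is whether a longer chain, such as hexyl, would give a lower number. Going by these compounds, it is also open whether an amine at the chain end would keep this level.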